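The source may hold more compounds than are shown below. What is called first, only, known or untested is meant among the compounds shown, and "the series" means these compounds.

Of the compounds shown here, three from one series have been measured in a functional assay on DLD-1 cells (Homo sapiens) for antiproliferative activity, read by CellTiter-Glo, with a stated time of 72 h; a higher number here means a weaker inhibitor, a lower number a stronger inhibitor. Compound 1 `CC1CCN(C2CCN(S(=O)(=O)c3cccc(C(F)(F)F)c3)CC2)CC1` carries a trifluoromethyl-bearing phenyl on its sulfonyl sulfur. In this assay compound 1 gives > 5000 nM, which is a limit of the assay and not a number. Compound 3 `Cc1cc(C)c(S(=O)(=O)N2CCC(c3ccccc3)CC2)c(C)c1` has a different core. In this assay compound 3 gives > 5000 nM, again a limit rather than a number. Compound 2 `CC1CCN(C2CCN(S(=O)(=O)c3cccnc3Cl)CC2)CC1` shares the core of compound 1 and bears a 2-chloropyridin-3-yl on the sulfonyl sulfur. In this assay compound 2 gives > 5000 nM, which is also a limit and not a number. Compound 2 thus stands where every measured compound stands: at the limit of > 5000 nM in this assay, at which 3 of the 3 values shown sit. Within the data shown here, no measured pair differs in only one place, so no measured step sets a scale for a single change.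

Compound 4 `CC1CCN(C2CCN(S(=O)(=O)c3cnc(Cl)s3)CC2)CC1` differs from compound 2 in one place: 2-chloro-1,3-thiazol-5-yl in place of 2-chloropyridin-3-yl on a sulfonyl sulfur. With all three measured values sitting at the limit, nothing in the data points to a gain from this exchange. The step from compound 2 to compound 4 is expected to be a step that the limit leaves unreadable from compound 2 to compound 4, that is, none beyond the scatter. Compound 4 is estimated to give 8000 nM in this assay, within a range from 3000 nM to 30000 nM, and most likely another limit.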

Compound 4, half-maximal inhibitory concentration: 1800 nM
The estimate for compound 4 lay 4.4-fold (0.65 log units) above the measured number; measured number below the stated range.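

In this assay, among these compounds, the group on the sulfonyl sulfur proves able to move the result on this shared core: 2-chloro-1,3-thiazol-5-yl in place of 2-chloropyridin-3-yl gives an at least 2.7-fold lower number from compound 2 to compound 4 (0.44 log units; beyond the scatter), a change the earlier compounds, with no pair differing in only one place, could not reveal. This step is a minimum and not an exact size: compound 2 gives > 5000 nM, which is a limit of the assay and not a number. Among the compounds shown, only compound 4 gives a number rather than a limit, so this exchange supplies the first readable foothold in the series: the limit of > 5000 nM in this assay, at which 3 of the 4 values shown sit.

The compounds shown do not separate the parts of the exchange, so it remains open whether the gain goes with the five-membered ring, with its sulfur, or with the second hetero atom. On these data alone, it also remains open whether the chlorine is needed at all, or whether an amine or a methoxy group in its place on the 1,3-thiazol-5-yl ring would keep, raise or lose the activity.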